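A few compounds are considered here, and "the series" means these few. Any claim that something is new, unique, unknown or untested is made for them only; others in the source may bear on it.

Measured so far in a functional assay on the whole organism for inhibition, with Mus musculus as the target, with stated times of 30 min and 2 h, at a dose of 10 mg/kg by the intraperitoneal route; on this read-out lower numbers stand for less inhibition and higher numbers for more inhibition at the one dose given (going by the name of the read-out):

compound 1, `COc1cccc(C(=O)NCc2ccc(CNS(=O)(=O)c3ccc(C)cc3)cc2)c1`: 28%
compound 2, `O=C(NCc1ccc(CNS(=O)(=O)c2ccccc2)cc1)c1cccnc1`: 53%
compound 3, `COc1ccccc1C(=O)NCc1ccc(CNS(=O)(=O)c2ccccc2)cc1`: "not active" (no number reported)

The three measured compounds share one core and differ only in the group attached to the amide carbonyl. In this assay compound 1 gives 28%, the lower of the two numbers reported. Compound 2 gives 53%, which lies beyond the usual scatter above compound 1. Compound 3 is reported only as "not active" (no number reported), with no number attached, so it cannot be placed against the other two.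

Compound 4, `Cc1ccc(S(=O)(=O)NCc2ccc(CNC(=O)c3cccc(Cl)c3)cc2)cc1`, has not yet been measured. It differs from compound 1 in a single place: chloro in place of methoxy on an aromatic carbon. For the measured compounds named here, no measured pair shows this particular change, so there is no step of known size to lean on. On that basis the expectation is a step from compound 1 to compound 4 that stays within the scatter, a number 2 percentage points higher from compound 1 to compound 4 (within the scatter). Compound 4 is therefore estimated at 30%, with a range from 10% to 50%.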

Compound 4, a percentage reported as inhibition, in the whole organism at one dose (the size of the read-out at that dose, not a potency): 57%
Compound 4: middle estimate off by 27 percentage points, on the low side, and the stated range ends below it.
By their numbers in this assay, from the lowest: compound 1; then compounds 2 and 4 (each within the scatter of the next).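

Among the earlier compounds, no two differed in just one place, so none could show whether this position on the aromatic ring matters in this assay. Compounds 1 and 4 provide that comparison: going from 3-methoxyphenyl to 3-chlorophenyl, with the rest of the molecule unchanged, gives a number 29 percentage points higher from compound 1 to compound 4 (beyond the scatter), so the group at this position can by itself shift the read-out. The exchange also replaces a group counted as a hydrogen-bond acceptor with one that is not, but no supporting data link the step to this or any other difference between the two groups.

With only one exchange shown at this position, it remains open whether a similar step would come with fluoro, an amine or a carboxylic acid. On these data alone, it also remains open whether chloro would give a similar result elsewhere on the same ring.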